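A few compounds are considered here, and "the series" means these few. Any claim that something is new, unique, unknown or untested is made for them only; others in the source may bear on it.

For the measured compounds named here, compound 2 `Cc1cc2nc(-c3nccs3)n(-c3ccc4c(N)nc(N)nc4c3)c2cc1C`, in an assay on isolated protein for inhibition of Dihydrofolate reductase (Homo sapiens), read by spectrophotometry, using NADPH, with a stated time of 10 min (on this read-out higher numbers stand for weaker inhibition and lower numbers for stronger inhibition), gives 93 nM, the lowest of the two numbers so far. Going by the values given here, its only neighbour is compound 1 `Cc1cc2ncn(-c3ccc4c(N)nc(N)nc4c3)c2cc1C`, which in this assay gives 1610 nM; the step of a 17-fold lower number from compound 1 to compound 2 (1.24 log units; beyond the scatter) is the one change measured here, the gain of a 1,3-thiazol-2-yl group. Compound 3 `Cc1cc2nc(-c3ccco3)n(-c3ccc4c(N)nc(N)nc4c3)c2cc1C` carries the change (furan-2-yl in place of 1,3-thiazol-2-yl on an aromatic carbon). Among the compounds with values here, no measured step follows a swap of one five-membered ring for another, so the single step from compound 1 to compound 2 only shows that the position accepts a small aromatic ring with a large drop in the number. Keeping such a ring while changing its atoms is expected to hold most of that effect, with at most a modest shift in either direction. Compound 3 is therefore expected at about 150 nM, between 50 nM and 500 nM, a step of a 1.6-fold higher number from compound 2 to compound 3 (0.21 log units; within the scatter) that is expected to stay near the scatter.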

Compound 3, inhibition constant: 943 nM
The estimate for compound 3 lay 6.3-fold (0.80 log units) below the measured number; the whole stated range lies below it.
By their numbers in this assay, from the lowest: compound 2; then compounds 3 and 1 (each within the scatter of the next).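

The position does not treat all small aromatic rings alike: in this assay, furan-2-yl in place of 1,3-thiazol-2-yl gives a 10-fold higher number from compound 2 to compound 3 (1.01 log units; beyond the scatter), so the earlier gain depends on which ring is present. Measured against hydrogen at this place, furan-2-yl gives a 1.7-fold lower number from compound 1 to compound 3 (0.23 log units; within the scatter), which lies within the scatter, so among the groups shown only 1,3-thiazol-2-yl brings a large drop in the number. Nothing available explains why two rings with the same count of heavy atoms differ so widely.

Going by these compounds, it remains open whether the ring nitrogen or the sulfur of 1,3-thiazol-2-yl matters more for this drop. On these data alone, it is also open whether a pyridin-2-yl ring or a simple amine at this place would behave more like 1,3-thiazol-2-yl or like furan-2-yl.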